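The source may report more compounds than this note shows. Statements on the series, on what has been measured and on what is new or still open speak of the compounds shown alone.

Compound 3 `N#CC1=C(N)Oc2c(N)cc3nc4ccccc4nc3c2C12C(=O)N(Cc1cnnn1-c1cccc(Br)c1)c1ccccc12` is known in a functional assay on MCF7 cells (Homo sapiens) for antiproliferative activity, read by MTT assay, with a stated time of 48 h (on this read-out lower numbers stand for stronger inhibition and higher numbers for weaker inhibition), only as a limit: compound 3 gives > 50000 nM, a limit of the assay and not a number. Compound 1 `Cc1ccc(C)c(-n2nncc2CN2C(=O)C3(C(C#N)=C(N)Oc4c3c3nc5ccccc5nc3c3ccccc43)c3ccccc32)c1` gives > 50000 nM, likewise a limit. Compound 2 `Cc1cc(C)cc(-n2nncc2CN2C(=O)C3(C(C#N)=C(N)Oc4c3c3nc5ccccc5nc3c3ccccc43)c3ccccc32)c1` gives > 50000 nM, again a limit. The step that the two limits leave unreadable from compound 1 to compound 2 is therefore unreadable, and the whole series shown so far sits at the limit of > 50000 nM in this assay, at which 3 of the 3 values shown sit.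

Compound 4 `N#CC1=C(N)Oc2c(N)cc3nc4ccccc4nc3c2C12C(=O)N(Cc1cnnn1-c1ccc([N+](=O)[O-])cc1[N+](=O)[O-])c1ccccc12` differs from compound 3 by 2,4-dinitrophenyl in place of 3-bromophenyl on an aromatic nitrogen. For the measured compounds named here, no measured step concerns this change, and every value shown is a limit, so no direction can be drawn from the numbers; the expected step that the limit leaves unreadable from compound 3 to compound 4 stays within the scatter, with the result likely to be reported again only as a limit. Compound 4 is expected at 60000 nM, between 20000 nM and 200000 nM.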

Compound 4, half-maximal inhibitory concentration: 20900 nM
Compound 4: middle estimate off by 2.9-fold (0.46 log units), on the high side; low and high end bracket the measured number.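

For the compounds shown here, on the aromatic nitrogen, 2,4-dinitrophenyl in place of 3-bromophenyl gives an at least 2.3-fold lower number from compound 3 to compound 4 (0.37 log units; beyond the scatter) in this assay, the first readable step. The aryl group at this place can therefore bring the read-out off the limit, though only compound 4 has a measured number. The other compounds stay at a limit, and steps between them cannot be read: the limit of > 50000 nM in this assay, at which 3 of the 4 values shown sit.

On these data alone, it remains open whether one nitro group alone gives this step. As far as these compounds go, an amine or a carboxylic acid on the phenyl ring also remains untested here.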